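Cytotoxicity notes on the aminopyrimidine-benzothiazole series

The source may report more compounds than this note shows. Statements on the series, on what has been measured and on what is new or still open speak of the compounds shown alone.

In an ADME assay on cells (Homo sapiens) for cytotoxicity, read by polymerase chain reaction, with a stated time of 3 days (on this read-out lower numbers stand for higher toxicity in this test and higher numbers for lower toxicity in this test), compound 1 `CNc1ccc2nc(-c3c(Cl)nc(N)nc3N[C@@H]3C[C@H](CO)[C@@H](O)[C@H]3O)sc2c1` gives 6000 nM. Compound 2 `Cc1nc(NC(C)(C)C)nc(N[C@@H]2C[C@H](CO)[C@@H](O)[C@H]2O)c1-c1nc2ccccc2s1` gives 12000 nM in this assay, the higher of the two numbers available, though its nearest neighbour compound 1 sits within the scatter of it, so the two are not separable. For the measured compounds named here, no step between measured compounds with a single change is available. Compound 3 `Cc1nc(NCc2cccs2)nc(N[C@@H]2C[C@H](CO)[C@@H](O)[C@H]2O)c1-c1nc2ccccc2s1` differs from compound 2 in one place: (thiophen-2-yl)methyl in place of tert-butyl on a nitrogen on an aromatic ring. The step from compound 2 to compound 3 is expected to be small, a 1.3-fold lower number from compound 2 to compound 3 (0.12 log units; within the scatter), with no direction claimed beyond the scatter. For compound 3 the estimate is 9000 nM, within 3000 nM to 30000 nM.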

Compound 3, half-maximal cytotoxic concentration: 6000 nM
Compound 3: the middle estimate sits 1.5-fold (0.18 log units) above what was measured; the range from low to high includes it.
By their numbers in this assay, from the lowest: compounds 1, 3 and 2 (each within the scatter of the next).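

At this position, on a nitrogen on an aromatic ring, the series now has its first single-change step in this assay: with (thiophen-2-yl)methyl in place of tert-butyl, a 2.0-fold lower number from compound 2 to compound 3 (0.30 log units; within the scatter), so the two compounds are not separable. A group with one five-membered aromatic ring therefore sits here with no step beyond the scatter. No evidence available bears on this step.

Still open, on these data alone, is how a longer alkyl chain or a carboxylic acid on this nitrogen would read, and whether any group here gives a step beyond the scatter.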